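Chalcone-type analogues: methyl to methoxy on the ketone aryl

The source may report more compounds than this note shows. Statements on the series, on what has been measured and on what is new or still open speak of the compounds shown alone.

Measured so far in a functional assay on MDA-MB-231 cells (Homo sapiens) for antiproliferative activity, read by MTT assay, with a stated time of 24 h; on this read-out higher numbers stand for weaker inhibition and lower numbers for stronger inhibition:
compound 1 `COc1ccc(C(=O)/C=C/c2cc(-c3cc(OC)c(OC)c(OC)c3)n3nc(-c4ccccc4)cc3n2)cc1` gives 13200 nM
compound 2 `COc1ccc(-c2cc(C(=O)/C=C/c3ccc(C)cc3)nc3cc(-c4ccccc4)nn23)cc1OC` gives 22600 nM
compound 3 `COc1ccc(-c2cc(/C=C/C(=O)c3ccc(C)cc3)nc3cc(-c4ccccc4)nn23)cc1OC` gives 19800 nM

Compound 3 sits second highest of the three numbers in this assay; its nearest neighbour is compound 2, its furthest compound 1, and both gaps are within the scatter. Among the compounds with values here, the only single-point step in the set is a 1.1-fold lower number from compound 2 to compound 3 (0.06 log units; within the scatter), and it swaps the two ends of the enone; it does not touch the aryl substituent and so says nothing direct about the next change.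

Compound 4 `COc1ccc(C(=O)/C=C/c2cc(-c3ccc(OC)c(OC)c3)n3nc(-c4ccccc4)cc3n2)cc1` differs from compound 3 by methoxy in place of methyl on an aromatic carbon. Within the data shown here, no measured pair isolates this change. Compound 1 carries a methoxy at the corresponding position of its ketone aryl but differs from compound 3 in a second place as well, so its value and that of compound 3 only show two numbers within the scatter of each other.

On this basis no step beyond the scatter is expected in this assay, and the estimate for compound 4 is 16000 nM with a range of 6000 nM to 40000 nM, the implied step being a 1.2-fold lower number from compound 3 to compound 4 (0.09 log units; within the scatter).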

Compound 4, half-maximal inhibitory concentration: 13900 nM
Compound 4: the middle estimate sits 1.2-fold (0.06 log units) above what was measured; measured number inside the range.
By their numbers in this assay, from the lowest: compounds 1, 4, 3 and 2 (each within the scatter of the next).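

In this assay there is now a direct pair for 4-methylphenyl to 4-methoxyphenyl: a 1.4-fold lower number from compound 3 to compound 4 (0.15 log units; within the scatter), which places this change, on an aromatic carbon para to a large group, inside the usual spread of repeated measurements. The wider change at the same end, which also reverses the enone, gives a 1.6-fold lower number from compound 2 to compound 4 (0.21 log units; within the scatter), so the two changes taken together also stay within the scatter. Within the data shown here, the first reading for hydrogen in place of methoxy on an aromatic carbon elsewhere in the molecule is a 1.1-fold higher number from compound 1 to compound 4 (0.02 log units; within the scatter), again within the scatter, so neither position has yet produced a step beyond it.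

From the compounds shown here alone, whether an amine or a carboxylic acid in place of the methoxy of the 4-methoxyphenyl would move the number beyond the scatter stays open. Nothing available bears on why these steps are as small as they are.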